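Replacing oxan-4-yl with 2-hydroxy-2-methylpropyl on an aromatic nitrogen

This account rests on a few compounds, and the source may have more. Where it says the series, first, only, none or still open, it means among the compounds named here.

Compound 1 `Cc1cc(Nc2nc(NCc3ccc(F)cc3F)nc3[nH]ncc23)n[nH]1`: 96.1 nM
Compound 2 `Cc1cc(Nc2nc(NCc3ccc(F)cc3F)nc3c2cnn3C2CCOCC2)n[nH]1`: 1750 nM

In an assay on isolated protein for inhibition of serine/threonine-protein kinase PAK 4 (Homo sapiens), read by HTRF, with a stated time of 60 min (a higher number here means a weaker inhibitor, a lower number a stronger inhibitor), compound 1 gives 96.1 nM, while compound 2 gives 1750 nM, the higher of the two numbers. Among the measured compounds shown here, the single measured step is an 18-fold higher number from compound 1 to compound 2 (1.26 log units; beyond the scatter), which sets oxan-4-yl against hydrogen at the same aromatic nitrogen. Compound 3 `Cc1cc(Nc2nc(NCc3ccc(F)cc3F)nc3c2cnn3CC(C)(C)O)n[nH]1` differs from compound 2 in one place: 2-hydroxy-2-methylpropyl in place of oxan-4-yl on an aromatic nitrogen. That earlier step bears on the change only in that it touches the same nitrogen; the entering group is neither hydrogen nor oxan-4-yl, so the data give no direct measure of it. He therefore expects a step toward a lower number that stays close to the scatter, as a 1.9-fold lower number from compound 2 to compound 3 (0.29 log units; within the scatter). For compound 3 he estimates 900 nM, with a range from 250 nM to 3000 nM.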

Compound 3, half-maximal inhibitory concentration: 655 nM
The estimate for compound 3 lay 1.4-fold (0.14 log units) above the measured number; measured number inside the range.
By their numbers in this assay, from the lowest: compound 1; then compound 3; then compound 2.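

In this assay, the size of the rise on substituting this aromatic nitrogen depends on the group placed there: 2-hydroxy-2-methylpropyl in place of oxan-4-yl gives a 2.7-fold lower number from compound 2 to compound 3 (0.43 log units; beyond the scatter). The open chain recovers only part of the loss, since replacing hydrogen with it still gives a 6.8-fold higher number from compound 1 to compound 3 (0.83 log units; beyond the scatter), and among these compounds the unsubstituted nitrogen of compound 1 keeps the lowest number. Nothing available explains either step.

Going by these compounds, what a methyl group, a 2-methylpropyl chain without the hydroxyl, or a chain ending in an amine or a carboxylic acid would do at this nitrogen remains open. The entering chain differs from oxan-4-yl both in having no ring and in carrying a hydrogen-bond donor, and the compounds shown do not separate the two.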